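From 2-methoxyphenyl to 2,4-dimethylphenyl on the shared core

The source may report more compounds than this note shows. Statements on the series, on what has been measured and on what is new or still open speak of the compounds shown alone.

Within the data shown here, in a functional assay on MCF7 cells (Homo sapiens) for antiproliferative activity, read by sulforhodamine B assay, with a stated time of 48 h (a higher number here means a weaker inhibitor, a lower number a stronger inhibitor), compound 2 (`CCCN1CCN(c2ccc(S(=O)(=O)Oc3ccccc3OC)cc2)C1=O`) gives 13000 nM and holds the only true number so far. Compound 1 (`CCCN1CCN(c2ccc(S(=O)(=O)Oc3ccccc3C)cc2)C1=O`) reads > 100000 nM in this assay and this is a limit of the assay, not a number. Compound 3 (`CCCN1CCN(c2ccc(S(=O)(=O)Oc3ccc(C)cc3C)cc2)C1=O`) carries 2,4-dimethylphenyl in place of 2-methoxyphenyl on an oxygen. Among the measured compounds shown here, only one measured step bears on this change: methoxy in place of methyl on an aromatic carbon gave an at least 7.6-fold lower number from compound 1 to compound 2 (0.88 log units; beyond the scatter) and it lies beyond the scatter. The new compound gives up that methoxy, so the step is read here in reverse, and a higher number than the 13000 nM of compound 2 is expected. For the measured compounds named here, no measured compound tests the second methyl group, and the limit leaves the true size of the earlier step open, so the expectation stays cautious and wide. The expected move is a 2.3-fold higher number from compound 2 to compound 3 (0.36 log units; beyond the scatter) in this assay towards weaker inhibition. Compound 3 is estimated at 30000 nM (expected range 6000 nM to 100000 nM).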

Compound 3, half-maximal inhibitory concentration: 1500 nM
Compound 3: the middle estimate sits 20-fold (1.30 log units) above what was measured; measured number below the stated range.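

On the oxygen bound to the sulfonyl sulfur, the methoxy group turns out not to be required for activity in this assay: 2,4-dimethylphenyl in place of 2-methoxyphenyl gives an 8.7-fold lower number from compound 2 to compound 3 (0.94 log units; beyond the scatter), so compound 3 goes against the advantage of methoxy over methyl that the earlier pair suggested. What the earlier compounds could not show is the weight of a single added methyl group on this ring, and methyl in place of hydrogen on an aromatic carbon gives an at least 66-fold lower number from compound 1 to compound 3 (1.82 log units; beyond the scatter), the largest step shown here. The reading of compound 1 is a limit of the assay and not a number, so this step has no upper size: the limit of > 100000 nM in this assay, at which 1 of the 3 values shown sits.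

The compounds shown leave open whether this gain belongs to the added methyl group alone or depends on the methyl group already present on the ring of compound 1, and a ring carrying methoxy together with that added methyl would separate the two. They also leave open whether an ethyl group, a chlorine atom or a carboxylic acid in the place of the added methyl would keep the activity of compound 3.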